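Taking the acetyl off compound 2

The compounds below may be only part of what the source reports. "The series", "measured", "known", "first", "only" and "open" are said of these compounds alone.

Values measured in an ADME assay on L6 cells (Rattus norvegicus) for cytotoxicity, read by resazurin assay, with a stated time of 70 h (a lower number here means that less compound is needed, a higher number that more compound is needed for the effect), are these.
Compound 1 `CC(=O)Nc1cnc2[nH]c(=O)n([C@H]3CC[C@H](C(C)C)CC3)c(=O)c2c1` gives 32000 nM
Compound 2 `CC(=O)Nc1cnc2[nH]c(=O)n([C@H]3CC[C@@H](C(C)C)CC3)c(=O)c2c1` gives 16000 nM

Compound 2 can be set only against compound 1, and the two values lie within the scatter of each other. The step between them is a 2.0-fold lower number from compound 1 to compound 2 (0.30 log units; within the scatter) and rests on the fact that compounds 1 and 2 differ only in the configuration as drawn as its whole structural difference.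

Compound 3 `CC(C)[C@H]1CC[C@@H](n2c(=O)[nH]c3ncc(N)cc3c2=O)CC1` is reached from compound 2 by one change, hydrogen in place of acetyl on a nitrogen on an aromatic ring or in short hydrogen in place of acetyl on a nitrogen on an aromatic ring, acetamido to amino.

For the measured compounds named here, the single measured step bears on this only weakly. It alters configuration alone and leaves the acetamido group in place. Going by the values given here, no measured step removes an acetyl, and the data give no direction for this change. In this assay no step beyond the scatter is expected, with a wide margin kept on both sides. The estimated middle is a 1.1-fold higher number from compound 2 to compound 3 (0.05 log units; within the scatter) and nothing more. For compound 3 the expected value is 18000 nM with an estimated range from 5000 nM to 55000 nM as its likely span.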

Compound 3, half-maximal effective concentration: 46000 nM
Beside the measured number, compound 3's estimate is 2.6-fold (0.41 log units) below it, and the stated range covers the measured number.
By their numbers in this assay, from the lowest: compounds 2, 1 and 3 (each within the scatter of the next, the first and the last beyond it).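

In this assay, the change from acetamido to amino gives the only step at this position among the compounds shown: a 2.9-fold higher number from compound 2 to compound 3 (0.46 log units; beyond the scatter). For the compounds shown here, the earlier pair kept the acetamido group in place and showed only what configuration does, with a 2.0-fold lower number from compound 1 to compound 2 (0.30 log units; within the scatter), so this step is the first sign that the group on this nitrogen matters in this assay, modest though the effect is, with more compound needed for the effect once the acetyl is replaced by hydrogen. Nothing at hand accounts for the direction or the size of this step.

The compounds shown leave open whether the same change would give a step of similar size in the other drawn configuration, that of compound 1, since this step has been read in one configuration only. They also leave open where other groups on this nitrogen would fall relative to amino and acetamido, for example a methyl group, a longer acyl chain such as propanoyl, or a methanesulfonyl group.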